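This account rests on a few compounds, and the source may have more. Where it says the series, first, only, none or still open, it means among the compounds named here.

Measured compounds:
- compound 1 `CCOC(=O)c1sc2nc(SC)nc(-c3cccc(OC)c3)c2c1N`: 1.5%
- compound 2 `COc1cccc(-c2nc(SC)nc3sc(C(=O)NCC#N)c(N)c23)c1`: 3.6%
- compound 3 `COc1cccc(-c2nc(SC)nc3sc(C(=O)N(C)C)c(N)c23)c1`: 4%

All three numbers come from a functional assay on HEK293 cells for agonist activity at Thyrotropin receptor (Homo sapiens), read by cAMP accumulation (on this read-out lower numbers stand for smaller maximal responses and higher numbers for larger maximal responses), and sit close to the bottom of the scale. Compound 3 gives the numerically largest of the three, yet a number 0.4 percentage points higher from compound 2 to compound 3 (within the scatter) and a number 2.5 percentage points higher from compound 1 to compound 3 (within the scatter) are both within the scatter, as is a number 2.1 percentage points higher from compound 1 to compound 2 (within the scatter), so the three compounds cannot be told apart on this read-out; what changes at the carbonyl carbon in this series has so far left the maximal response unchanged.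

Compound 4 `COc1cccc(-c2nc(SC)nc3sc(C(=O)N(C)C(C)(C)C)c(N)c23)c1` is the next member. The change from compound 3 is tert-butyl in place of methyl on an amide-type nitrogen. For the measured compounds named here, the step that bears most directly on it is the one from compound 2 to compound 3, which also altered the group on the amide-type nitrogen side of the carbonyl and stayed within the scatter; the two steps from compound 1 did the same. Going by the values given here, nothing among the measured compounds points to a move beyond the scatter for compound 4, so the expected step is no change at the digits printed from compound 3 to compound 4 (within the scatter), essentially none. Compound 4 is therefore estimated at 4% in this assay, with a range from 0% to 12%.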

Compound 4, largest response reached (reported as efficacy), in percent of the reference or control that the assay uses: 3.6%
Compound 4: middle estimate off by 0.4 percentage points, on the high side; the range from low to high includes it.
By their numbers in this assay, from the lowest: compounds 1, 2, 4 and 3 (each within the scatter of the next).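

In this assay, for the compounds shown here, going from methyl to tert-butyl on the amide-type nitrogen, from 1 heavy atom to 4, gives a number 0.4 percentage points lower from compound 3 to compound 4 (within the scatter), the first step confined to a single substituent on that nitrogen. Measured against the other groups on the carbonyl carbon, compound 4 also stays indistinguishable, with no change at the digits printed from compound 2 to compound 4 (within the scatter) and a number 2.1 percentage points higher from compound 1 to compound 4 (within the scatter), so the added bulk of tert-butyl leaves all four compounds together near the bottom of the scale. No supporting evidence bears on this flat result.

Open, going by these compounds, is whether any group on the carbonyl carbon can separate itself from these four on this read-out, for example a free carboxylic acid, a primary amide or an amide carrying a longer chain ending in an amine. On these data alone, all four compounds also share the rest of the core, so the effect of a change outside the carbonyl substituent, such as an amine or a longer chain in place of the methylthio group, remains unknown.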